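The compounds below may be only part of what the source reports. "The series", "measured", "known", "first", "only" and "open" are said of these compounds alone.

Compound 1 `COc1ccc(NC2=CC(=O)c3c(nc4n3[C@H]3OC[C@@H](O)[C@H]3OC4)C2=O)cc1` is measured in a functional assay on HeLa cells (Homo sapiens) for inhibition, read by sulforhodamine B assay (a higher number here means a weaker inhibitor, a lower number a stronger inhibitor), only as a limit, > 8000 nM. Compound 2 `CCOc1ccc(NC2=CC(=O)c3c(nc4n3[C@H]3OC[C@@H](O)[C@H]3OC4)C2=O)cc1` gives in this assay 14400 nM. Compound 3 `COc1ccccc1NC1=CC(=O)c2c(nc3n2[C@H]2OC[C@@H](O)[C@H]2OC3)C1=O` gives in this assay 7460 nM.

Of the two numbers shown, compound 3 carries the lowest, with compound 2 nearest: a 1.9-fold lower number from compound 2 to compound 3 (0.29 log units; within the scatter). The value of compound 1 is a limit of > 8000 nM in this assay, at which 1 of the 3 values shown sits, and so cannot be ordered against compound 3, which is why the step from compound 1 to compound 3 reads only as an at least 1.0-fold lower number from compound 1 to compound 3 (0.03 log units; that floor lies within the scatter). The step from compound 1 to compound 2, a step that the limit leaves unreadable from compound 1 to compound 2, is likewise unreadable. All three measured compounds thus sit close together at weak inhibition.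

Compound 4 `O=C1C(NC2CCCC2)=CC(=O)c2c1nc1n2[C@H]2OC[C@@H](O)[C@H]2OC1` is not yet measured. It differs from compound 3 as follows: cyclopentyl in place of 2-methoxyphenyl on an amine nitrogen. Among the compounds with values here, none of the measured steps touches this kind of change; each of them moves or lengthens an alkoxy group on an aromatic ring that stays in place, whereas here the ring itself leaves. Within the data shown here, no measured step therefore bears directly on it, and the expectation rests only on the narrow range of the three measured compounds. The step from compound 3 to compound 4 is expected to be about a 1.2-fold higher number from compound 3 to compound 4 (0.08 log units; within the scatter), which means no change beyond the scatter. Compound 4 is estimated at 9000 nM, with a range from 3000 nM to 27000 nM.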

Compound 4, half-maximal inhibitory concentration: > 16000 nM
Compound 4: no number, only a limit (the forecaster's own chance of this, stated with the estimate: 35%); at least 1.7-fold (0.24 log units) between middle value and limit.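

Compound 4 is recorded in this assay only as a limit: the limit of > 16000 nM in this assay, at which 1 of the 4 values shown sits.

Exchanging the aromatic ring on the amine nitrogen for a saturated one gives an at least 2.1-fold higher number from compound 3 to compound 4 (0.33 log units; beyond the scatter), so at this position the change from (2-methoxyphenyl)amino to cyclopentylamino weakens inhibition, and this is the only readable step among the compounds shown that is printed as beyond the scatter. The earlier readable steps, which only altered the alkoxy-bearing aromatic group, did not separate any compounds in this way, yet the same exchange measured against the 4-ethoxyphenyl group gives only an at least 1.1-fold higher number from compound 2 to compound 4 (0.04 log units; that floor lies within the scatter), so the weakening is established against compound 3 alone and not against compound 2.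

From the compounds shown here alone, the step involving compound 1 cannot be read, and the true size of the loss remains unknown while compound 4 stands as a limit. Going by these compounds, it also remains open whether the result follows from losing the aromatic ring, from the ring size or from losing the methoxy group, which a plain phenyl or a cyclohexyl group on the same amine nitrogen would help to separate.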